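Cytotoxicity notes on a nucleoside series, toward compound 4

The source may hold more compounds than are shown below. What is called first, only, known or untested is meant among the compounds shown, and "the series" means these compounds.

Compound 1, `[N-]=[N+]=NCc1ncnc2c1ncn2[C@@H]1O[C@H](CO)[C@@H](O)[C@H]1O`: in a functional assay on Huh-7 cells (Homo sapiens) for cytotoxicity, read by MTT assay, with a stated time of 3 days (on this read-out higher numbers stand for lower toxicity in this test and lower numbers for higher toxicity in this test), compound 1 gives > 250000 nM, which is a limit of the assay.
Compound 2, `OC[C@H]1O[C@@H](n2cnc3c(COc4ccccn4)ncnc32)[C@H](O)[C@@H]1O`: in this assay compound 2 gives > 250000 nM, again a limit of the assay.
Compound 3, `CC(=O)N(Cc1ccccc1)Cc1ncnc2c1ncn2[C@@H]1O[C@H](CO)[C@@H](O)[C@H]1O`: in this assay compound 3 gives > 100000 nM, also a limit of the assay.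

Compound 2 stands at the limit of > 250000 nM in this assay, at which 2 of the 3 values shown sit, the same limit that holds compound 1, while compound 3 sits at the limit of > 100000 nM in this assay, at which 1 of the 3 values shown sits. Among the compounds with values here, no compound in this set yields a numerical cytotoxic concentration. Within the data shown here, the one directly measured step, a step that the two limits leave unreadable from compound 1 to compound 2, is unreadable, as both ends are limits.

Compound 4 is `CN(Cc1ccccc1)Cc1ncnc2c1ncn2[C@@H]1O[C@H](CO)[C@@H](O)[C@H]1O`. Relative to compound 2 the change is benzyl(methyl)amino in place of (pyridin-2-yl)oxy on a saturated chain carbon bound to an aromatic carbon. Among the measured compounds shown here, no measured step bears on this change; the only measured step is unreadable, and compound 3, which also carries a benzyl-bearing nitrogen on the same saturated chain carbon, likewise stands at a limit. The step expected for a number no higher from compound 2 to compound 4 (the limit leaves the size open) is therefore none beyond the scatter, with compound 4 most likely reported again as a limit. Compound 4 is estimated at 250000 nM, within 100000 nM to 500000 nM.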

Compound 4, half-maximal cytotoxic concentration: 9000 nM
Compound 4: middle estimate off by 28-fold (1.44 log units), on the high side; the whole stated range lies above it.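

With benzyl(methyl)amino on a saturated chain carbon bound to an aromatic carbon, this position proves not indifferent in this assay: there is an at least 27-fold lower number from compound 2 to compound 4 (1.44 log units; beyond the scatter) with (pyridin-2-yl)oxy leaving, and an at least 27-fold lower number from compound 1 to compound 4 (1.44 log units; beyond the scatter) with azido leaving. The substituent on the amine nitrogen counts as well: there is an at least 11-fold lower number from compound 3 to compound 4 (1.04 log units; beyond the scatter) with methyl in place of acetyl, so the benzyl group on that nitrogen does not by itself bring the number down. Each of these steps starts from a limit of the assay, so each gives only a smallest size.

Open, going by these compounds, is how the number moves with a dimethylamino group or a piperidine on the same carbon, or with a phenethyl group in place of benzyl on the amine nitrogen. No measurement shown gives a cause for these steps.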